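Swapping the chain on the core nitrogen for a small ring

The compounds below may be only part of what the source reports. "The series", "measured", "known", "first", "only" and "open" are said of these compounds alone.

Compound 1 `CCCCn1ccc(-c2ccc(Oc3cccnc3C)cc2)c(C#N)c1=O`: 228%
Compound 2 `Cc1ncccc1Oc1ccc(-c2ccn(CCC(C)C)c(=O)c2C#N)cc1`: 256%

In a functional assay on CHO cells for positive allosteric modulation of metabotropic glutamate receptor 2 (Homo sapiens), read by scintillation counting and GTPgammaS binding, with a stated time of 30 min (on this read-out lower numbers stand for smaller maximal responses and higher numbers for larger maximal responses), compound 2 stands highest of the two measured numbers, with compound 1 the nearest and lower. For the measured compounds named here, the one measured step, a number 28 percentage points higher from compound 1 to compound 2 (beyond the scatter), shows that changing the chain on the core nitrogen can move the number beyond the scatter. Compound 3 `Cc1ncccc1Oc1ccc(-c2ccn(CC3CC3)c(=O)c2C#N)cc1` differs from compound 2 by cyclopropyl in place of isobutyl on a saturated chain carbon bound to an aromatic nitrogen. Going by the values given here, no measured step covers such a swap, so the direction is uncertain; a step no larger than the measured one, a number 21 percentage points lower from compound 2 to compound 3 (beyond the scatter), is expected. Compound 3 is estimated at 235%, in a range from 190% to 280%.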

Compound 3, largest response reached (Emax), in percent of the reference or control that the assay uses: 155%
The estimate for compound 3 lay 80 percentage points above the measured number, outside the stated range (below it).
By their numbers in this assay, from the lowest: compound 3; then compound 1; then compound 2.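

At this place, on a saturated chain carbon bound to an aromatic nitrogen, cyclopropyl in place of isobutyl gives a number 101 percentage points lower from compound 2 to compound 3 (beyond the scatter) in this assay. Cyclopropyl in place of propyl gives a number 73 percentage points lower from compound 1 to compound 3 (beyond the scatter), so with these open chains the small ring lowers the maximal response, whereas the earlier methyl change raised it. Nothing available explains this drop. The compounds shown leave open whether a larger ring, such as cyclobutyl or cyclohexyl, would also lower the number. On these data alone, what a chain carrying an amine would do here also remains open.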